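The source may report more compounds than this note shows. Statements on the series, on what has been measured and on what is new or still open speak of the compounds shown alone.

The series shares one core, seen in compound 1 `Nc1nc(NC2CC2)c2ncn(/C=C3/CC3(CO)CO)c2n1`, compound 2 `CC(C)CSc1nc(N)nc2c1ncn2/C=C1/CC1(CO)CO`, compound 3 `Nc1nc(OCC(F)(F)F)c2ncn(/C=C3/CC3(CO)CO)c2n1` and the as yet unmeasured compound 4 `Nc1nc(SCc2ccccc2)c2ncn(/C=C3/CC3(CO)CO)c2n1`. In an ADME assay on MOLT-3 cells (Homo sapiens) for cytotoxicity, with a stated time of 7 days (on this read-out higher numbers stand for lower toxicity in this test and lower numbers for higher toxicity in this test), compound 1 gives > 20000 nM, which is a limit of the assay and not a number. Compound 3 likewise gives > 20000 nM, again a limit. For compound 2 the result is "not determined" (no result reported). Compound 1 therefore stands only at a limit, with no single number attached to it. Within the data shown here, the one step between measured compounds that differ in one place, a step that the two limits leave unreadable from compound 1 to compound 3, is not readable from two limits; the only thing on show is the limit of > 20000 nM in this assay, at which 2 of the 3 values shown sit.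

Compound 4 differs from compound 1 by benzylsulfanyl in place of cyclopropylamino on an aromatic carbon. Among the measured compounds shown here, no measured step tracks this change. What bears on it is that compound 1 rests at a limit in this assay and compound 3, with 2,2,2-trifluoroethoxy in that place, does the same, so the earlier exchange at this carbon left no readable movement. The step expected in this assay is a number no higher from compound 1 to compound 4 (the limit leaves the size open), nothing beyond the scatter, most likely ending again at the limit. Compound 4 is expected to come out near 20000 nM, within 8000 nM to 50000 nM.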

Compound 4, half-maximal cytotoxic concentration: > 20000 nM
Compound 4: only a limit was reported (the forecaster's own chance of this, stated with the estimate: 75%); the middle value lies on the limit itself.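

Compound 4, like compound 1 and compound 3, stands only at a limit in this assay, so no step among these three compounds can be read: the limit of > 20000 nM in this assay, at which 3 of the 4 values shown sit.

The compounds shown leave open whether cyclopropylamino, 2,2,2-trifluoroethoxy and benzylsulfanyl on this aromatic carbon differ at all in this assay, since none of the three compounds has a single number.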